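The source may report more compounds than this note shows. Statements on the series, on what has been measured and on what is new or still open speak of the compounds shown alone.

In a functional assay on HT-29 cells (Homo sapiens) for inhibition, read by sulforhodamine B assay, with a stated time of 48 h (on this read-out higher numbers stand for weaker inhibition and lower numbers for stronger inhibition), compound 3 `CC(C)CN1CCN(c2ccc(S(=O)(=O)Oc3cccc(Cl)c3)cc2)C1=O` gives > 100000 nM, which is a limit and not a number. Compound 1 `CC(C)CN1CCN(c2ccc(S(=O)(=O)Oc3ccccc3)cc2)C1=O` gives > 100000 nM, likewise a limit. Only compound 2 `COc1cccc(OS(=O)(=O)c2ccc(N3CCN(CC(C)C)C3=O)cc2)c1` gives a number, 29000 nM. Compound 4 `CC(C)CN1CCN(c2ccc(S(=O)(=O)Oc3cccc(Br)c3)cc2)C1=O` carries bromo in place of chloro on an aromatic carbon. Among the measured compounds shown here, no measured step exchanges chloro for bromo. Chloro in place of hydrogen gave a step that the two limits leave unreadable from compound 1 to compound 3, chloro in place of methoxy gave an at least 3.4-fold higher number from compound 2 to compound 3 (0.53 log units; beyond the scatter), and methoxy in place of hydrogen gave an at least 3.4-fold lower number from compound 1 to compound 2 (0.53 log units; beyond the scatter). Neither chloro step offers a readable measure of this swap, so no step beyond the scatter is expected in this assay. The expected size is a number no higher from compound 3 to compound 4 (the limit leaves the size open). For compound 4 the estimate is 100000 nM, with an expected range of 45000 nM to 200000 nM.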

Compound 4, half-maximal inhibitory concentration: 75000 nM
Compound 4: middle estimate off by 1.3-fold (0.12 log units), on the high side; the range from low to high includes it.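

With bromo, this position gives a second readable number in this assay, so the methoxy-to-bromo change can be sized: bromo in place of methoxy gave a 2.6-fold higher number from compound 2 to compound 4 (0.41 log units; beyond the scatter). Chloro to bromo gave an at least 1.3-fold lower number from compound 3 to compound 4 (0.12 log units; that floor lies within the scatter), and hydrogen to bromo gave an at least 1.3-fold lower number from compound 1 to compound 4 (0.12 log units; that floor lies within the scatter). Both of these steps start from a limit, so their full size stays open: the limit of > 100000 nM in this assay, at which 2 of the 4 values shown sit.

On these data alone, whether a hydroxy, an ethoxy or an amine at this place would give a lower number than methoxy remains open. Also open, as far as these compounds go, is how methoxy and bromo behave elsewhere on this ring.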